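This account rests on a few compounds, and the source may have more. Where it says the series, first, only, none or still open, it means among the compounds named here.

Of the compounds shown here, three have so far been measured in an assay on nucleic acid for binding affinity to Nucleic Acid, at pH 6.5, tested at 3 uM; on this read-out lower numbers stand for weaker stabilisation of the target and higher numbers for stronger stabilisation of the target against heat. Compound 1 `CN(C)CCCNC(=O)c1cc(NC(=O)c2cc(NC(=O)c3nc(NC=O)cn3C)cn2CCCN)cn1C` gives 0 degrees C. Compound 3 `CN(C)CCCNC(=O)c1cc(NC(=O)c2cc(NC(=O)c3nc(NC=O)cn3C)cn2C)cn1C` gives 2 degrees C; what separates the two is hydrogen in place of 2-aminoethyl on a saturated chain carbon bound to an aromatic nitrogen, and that single change produced a number 2.0 degrees C higher from compound 1 to compound 3 (beyond the scatter). Compound 2 `CN(C)CCCNC(=O)c1cc(NC(=O)c2nc(NC(=O)c3cc(NC=O)cn3CCCN)cn2C)cn1C` is built from the same atoms as compound 1, joined differently, and the difference between the two cores is not broken down here. In this assay compound 2 gives 0 degrees C, level with compound 1 at the digits reported.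

Compound 4 `CN(C)CCCNC(=O)c1cc(NC(=O)c2nc(NC(=O)c3cc(NC=O)cn3C)cn2C)cn1C` stands to compound 2 as compound 3 stands to compound 1: the change is hydrogen in place of 2-aminoethyl on a saturated chain carbon bound to an aromatic nitrogen, at the same place in both pairs, so it is the same change made on a different core. Because the earlier instance gave a number 2.0 degrees C higher from compound 1 to compound 3 (beyond the scatter) from a starting point that compound 2 matches at 0 degrees C, a similar move is expected here, allowing for the different core. The step from compound 2 to compound 4 is estimated at a number 1.5 degrees C higher from compound 2 to compound 4 (beyond the scatter). Compound 4 is accordingly expected at 1.5 degrees C, most plausibly between 0 degrees C and 3 degrees C.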

Compound 4, shift of the target's melting temperature: 3 degrees C
Estimate against measurement, compound 4: 1.5 degrees C below; low and high end bracket the measured number.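

In this assay, cutting the 3-aminopropyl chain back to methyl gives a number 3.0 degrees C higher from compound 2 to compound 4 (beyond the scatter). Set beside the earlier step, the change carries over from one core to the other, in direction and, as far as the scatter allows, in size: the same change on two cores in this assay, a number 2.0 degrees C higher (beyond the scatter) from compound 1 to compound 3 and a number 3.0 degrees C higher (beyond the scatter) from compound 2 to compound 4, 1.0 degrees C apart, within the scatter of two such steps. Within the data shown here, this rests on only two pairs of compounds, so it supports carrying the change between these two cores but does not show that it would hold on any other core, nor does it explain why methyl gives the higher number.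

The compounds shown carry only 3-aminopropyl or methyl at this place, so the two pairs cannot tell whether the difference comes from the length of the chain or from the amine at its end. A propyl chain without the amine would separate those two, and a longer chain ending in an amine or a chain ending in a carboxylic acid would show how far the trend extends.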